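From compound 3 to compound 4: fluoro for ethyl

A few compounds are considered here, and "the series" means these few. Any claim that something is new, unique, unknown or untested is made for them only; others in the source may bear on it.

Values in an ADME assay on microsomes from liver (Homo sapiens) for metabolic stability, with a stated time of 10 min; a lower number here means that less of the compound is left, a higher number that more of the compound is left:
- compound 1 `CC[C@]1(C(=O)O)CC[C@H](C(=O)N2CC[C@](c3ccc(C(F)(C(F)(F)F)C(F)(F)F)cc3)(S(=O)(=O)c3ccc(F)cc3)C2)CC1` gives 100% (measured)
- compound 2 `O=C([C@H]1CC[C@H](c2nnn[nH]2)CC1)N1CC[C@](c2ccc(C(F)(C(F)(F)F)C(F)(F)F)cc2)(S(=O)(=O)c2ccc(F)cc2)C1` gives 100% (measured)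
- compound 3 `CCC1(C(=O)N2CC[C@](c3ccc(C(F)(C(F)(F)F)C(F)(F)F)cc3)(S(=O)(=O)c3ccc(F)cc3)C2)CCS(=O)(=O)CC1` gives 3% (measured)

Compound 3 stands lowest of the three, far under the other two. Compound 4 `O=C(N1CC[C@](c2ccc(C(F)(C(F)(F)F)C(F)(F)F)cc2)(S(=O)(=O)c2ccc(F)cc2)C1)C1(F)CCS(=O)(=O)CC1` differs from it by fluoro in place of ethyl on a saturated ring carbon. Among the measured compounds shown here, no measured step makes this exchange. The closest are a number 97 percentage points lower from compound 1 to compound 3 (beyond the scatter) and a number 97 percentage points lower from compound 2 to compound 3 (beyond the scatter) (both large), but each replaces the whole group on the carbonyl carbon, so they guide only loosely. A moderate rise is expected, estimated as a number 12 percentage points higher from compound 3 to compound 4 (beyond the scatter) (with wide uncertainty). Compound 4 is expected at 15% (estimated range 3% to 50%).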

Compound 4, percent of the compound remaining: 100%
For compound 4 the middle estimate is 85 percentage points below the measured one; the measured number lies above the stated range.
By their numbers in this assay, from the lowest: compound 3; then compounds 1, 2 and 4 (each within the scatter of the next).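

In this assay, fluoro in place of ethyl on this saturated ring carbon gives a number 97 percentage points higher from compound 3 to compound 4 (beyond the scatter), so the low reading of compound 3 does not belong to the 1,1-dioxothian ring as such. The 4-fluoro-1,1-dioxothian-4-yl group stands level with the two other groups on the carbonyl carbon, with no change at the digits printed from compound 2 to compound 4 (within the scatter) and no change at the digits printed from compound 1 to compound 4 (within the scatter). Nothing on hand explains the step.

Open, as far as these compounds go, is whether the step belongs to fluoro itself or to the loss of ethyl. A methyl or hydroxyl group on the same ring carbon would separate the two.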